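Amine swap on the shared core of compound 1

A few compounds are considered here, and "the series" means these few. Any claim that something is new, unique, unknown or untested is made for them only; others in the source may bear on it.

Compound 1 `O=C1C=C(N2CCC2)C(=O)c2c1nc1n2[C@H]2OC[C@@H](O)[C@H]2OC1` stands at the limit of a functional assay on HeLa cells (Homo sapiens) for inhibition, read by sulforhodamine B assay; a lower number here means a stronger inhibitor, a higher number a weaker inhibitor: it gives > 16000 nM, which is a limit and not a number, as the limit of > 16000 nM in this assay, at which 1 of the 2 values shown sits, records. Compound 2 `O=C1C(Nc2ccc(Br)cc2)=CC(=O)c2c1nc1n2[C@H]2OC[C@@H](O)[C@H]2OC1` gives 5220 nM in this assay. Among the measured compounds shown here, no single-change step between measured compounds is available. Compound 3 `CCCN(CCC)C1=CC(=O)c2nc3n(c2C1=O)[C@H]1OC[C@@H](O)[C@H]1OC3` differs from compound 1 by dipropylamino in place of azetidin-1-yl on a double-bonded ring carbon. For the measured compounds named here, with no measured step to guide this change, a step of an at least 1.0-fold lower number from compound 1 to compound 3 (0.02 log units; that floor lies within the scatter) is expected, not clearly beyond the scatter in either direction. Compound 3 is therefore estimated at 15000 nM, within a range from 5000 nM to 40000 nM.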

Compound 3, half-maximal inhibitory concentration: > 16000 nM
Compound 3: a limit, no number; the forecaster's own chance of this, stated with the estimate: 45%; middle value at least 1.0-fold (0.02 log units) away from the limit.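

No step can be read from compound 1 to compound 3, as both stand at a limit and not a number: the limit of > 16000 nM in this assay, at which 2 of the 3 values shown sit. The compounds shown leave open whether azetidin-1-yl and dipropylamino differ at all in this assay.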